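The compounds below may be only part of what the source reports. "The series", "measured", "known", "first", "only" and "open" are said of these compounds alone.

In a functional assay on the whole organism with Scenedesmus acutus as the target, with a stated time of 20 h (on this read-out higher numbers stand for weaker inhibition and lower numbers for stronger inhibition), three compounds sharing one core have been measured. Compound 1 (`COC(=O)c1cc(N2C(=O)C3=C(CCCC3)C2=O)ccc1Cl`) gives 1620 nM, compound 2 (`CCCCOC(=O)c1cc(N2C(=O)C3=C(CCCC3)C2=O)ccc1Cl`) gives 7760 nM, and compound 3 (`CC(C)COC(=O)c1cc(N2C(=O)C3=C(CCCC3)C2=O)ccc1Cl`) gives 15500 nM. Compound 3 therefore sits level with compound 2, and both lie clearly on the weaker side of compound 1. The gap to its nearest neighbour is a 2.0-fold higher number from compound 2 to compound 3 (0.30 log units; within the scatter), while the gap to the far end of the set is a 9.6-fold higher number from compound 1 to compound 3 (0.98 log units; beyond the scatter).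

Compound 4 (`CCCCCOC(=O)c1cc(N2C(=O)C3=C(CCCC3)C2=O)ccc1Cl`) alters only the chain: butyl in place of isopropyl on a saturated chain carbon bound to an oxygen next to a carbonyl group. Among the measured compounds shown here, two measured steps bear on this. Adding propyl in place of hydrogen gave a 4.8-fold higher number from compound 1 to compound 2 (0.68 log units; beyond the scatter), a modest change, but swapping propyl for isopropyl gave only a 2.0-fold higher number from compound 2 to compound 3 (0.30 log units; within the scatter). Among the larger chains, then, the data show little movement, although no chain of this length has been tested. The expected change, no larger than the scatter, is a 1.6-fold lower number from compound 3 to compound 4 (0.19 log units; within the scatter). Compound 4 is estimated at 10000 nM, with an expected range of 4000 nM to 25000 nM.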

Compound 4, half-maximal inhibitory concentration: 5370 nM
The estimate for compound 4 lay 1.9-fold (0.27 log units) above the measured number; the range from low to high includes it.
By their numbers in this assay, from the lowest: compound 1; then compounds 4, 2 and 3 (each within the scatter of the next, the first and the last beyond it).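

In this assay, butyl in place of isopropyl on a saturated chain carbon bound to an oxygen next to a carbonyl group gives a 2.9-fold lower number from compound 3 to compound 4 (0.46 log units; beyond the scatter), so at this position two chains of similar size can differ beyond the scatter, which the earlier step between larger chains did not show. Extending the straight chain by methyl gives a 1.4-fold lower number from compound 2 to compound 4 (0.16 log units; within the scatter), which is within the scatter, while a 3.3-fold higher number from compound 1 to compound 4 (0.52 log units; beyond the scatter) shows that the pentyloxycarbonyl compound remains on the weaker side of the methyl ester. Nothing given here explains these differences.

The compounds shown leave open whether a longer chain, such as hexyl, would continue this flat stretch. They also leave open how a chain ending in an amine or a carboxylic acid would behave at this position.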